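The compounds below may be only part of what the source reports. "The series", "measured", "known", "first", "only" and "open" are said of these compounds alone.

Compounds measured in an assay on isolated protein for inhibition of acyl-CoA:cholesterol acyltransferase (Oryctolagus cuniculus); a higher number here means a weaker inhibitor, a lower number a stronger inhibitor: compound 1 `CCc1ccc(NC(=O)Nc2c(C(C)C)cccc2C(C)C)cc1` gives 100 nM; compound 2 `CCCCc1ccc(NC(=O)Nc2c(C(C)C)cccc2C(C)C)cc1` gives 29 nM.

Among the measured compounds shown here, compound 2 holds the lowest of the two numbers, and compound 1 is its only neighbour. For the measured compounds named here, the single measured step, a 3.4-fold lower number from compound 1 to compound 2 (0.54 log units; beyond the scatter), is the one comparison that bears on the chain at this position. Compound 3 `Cc1ccc(NC(=O)Nc2c(C(C)C)cccc2C(C)C)cc1` differs from compound 2 by hydrogen in place of propyl on a saturated chain carbon bound to an aromatic carbon. This change runs in the opposite direction to the measured step and shortens the chain further, so a rise in the number beyond the scatter is expected, roughly of the size an 8.6-fold higher number from compound 2 to compound 3 (0.94 log units; beyond the scatter). Compound 3 is therefore estimated at 250 nM, within a range from 100 nM to 700 nM.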

Compound 3, half-maximal inhibitory concentration: 250 nM
Compound 3: the middle estimate sits on the measured number at the digits printed; low and high end bracket the measured number.
By their numbers in this assay, from the lowest: compound 2; then compound 1; then compound 3.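

In this assay the three compounds now form a series of methyl, ethyl and butyl at one place, and the number falls as the chain lengthens, with no compound shown going against this order. The step of an 8.6-fold higher number from compound 2 to compound 3 (0.94 log units; beyond the scatter) spans the whole series and the step of a 2.5-fold higher number from compound 1 to compound 3 (0.40 log units; beyond the scatter) shows that even the shortest change here lies beyond the scatter. No available evidence accounts for this order. Still open, as far as these compounds go, is whether the number keeps falling with a longer chain such as hexyl, and how a chain ending in an amine or a carboxylic acid would compare.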